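Amide-substituent changes on a spiro series: compound 4 expectation

A few compounds are considered here, and "the series" means these few. Any claim that something is new, unique, unknown or untested is made for them only; others in the source may bear on it.

Measured compounds in an assay on HEK293 cells for displacement of a labelled ligand from NPC1-like intracellular cholesterol transporter 1 (Homo sapiens); on this read-out higher numbers stand for weaker inhibition and lower numbers for stronger inhibition:
compound 1 `CCC1CCCN(C(=O)CN2CN(c3ccccc3)C3(CCN(C(=O)c4ccc(C5CCCCC5)cc4)CC3)C2=O)C1` gives 2600 nM;
compound 2 `COC(=O)CCCNC(=O)CN1CN(c2ccccc2)C2(CCN(C(=O)c3ccc(C4CCCCC4)cc3)CC2)C1=O` gives 2500 nM;
compound 3 `CC1CCCN(C(=O)CN2CN(c3ccccc3)C3(CCN(C(=O)c4ccc(C5CCCCC5)cc4)CC3)C2=O)C1` gives 3600 nM.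

Compound 3 has the highest of the three numbers, but a 1.4-fold higher number from compound 1 to compound 3 (0.14 log units; within the scatter) and a 1.4-fold higher number from compound 2 to compound 3 (0.16 log units; within the scatter) are both within the scatter, so no order among the three is established. Compound 4 `CS(=O)(=O)N1CCN(C(=O)CN2CN(c3ccccc3)C3(CCN(C(=O)c4ccc(C5CCCCC5)cc4)CC3)C2=O)CC1` carries 4-(methylsulfonyl)piperazin-1-yl in place of 3-methylpiperidin-1-yl on a carbonyl carbon. Among the compounds with values here, the steps that bear on this are the two exchanges on the same carbonyl carbon, a 1.0-fold lower number from compound 1 to compound 2 (0.02 log units; within the scatter) and a 1.4-fold higher number from compound 2 to compound 3 (0.16 log units; within the scatter), neither beyond the scatter. In this assay no step beyond the scatter is therefore expected for the change from compound 3 to compound 4, giving an estimated 1.2-fold lower number from compound 3 to compound 4 (0.08 log units; within the scatter). Compound 4 is expected at 3000 nM, with a range from 1200 nM to 7500 nM.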

Compound 4, half-maximal inhibitory concentration: 6300 nM
Beside the measured number, compound 4's estimate is 2.1-fold (0.32 log units) below it; the range from low to high includes it.
By their numbers in this assay, from the lowest: compounds 2, 1, 3 and 4 (each within the scatter of the next, the first and the last beyond it).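

Within the data shown here, on this carbonyl carbon, 4-(methylsulfonyl)piperazin-1-yl gives the first steps beyond the scatter in this assay for this series, modest in size, against 3-ethylpiperidin-1-yl (a 2.4-fold higher number from compound 1 to compound 4 (0.38 log units; beyond the scatter)) and against (3-(methoxycarbonyl)propyl)amino (a 2.5-fold higher number from compound 2 to compound 4 (0.40 log units; beyond the scatter)). Against 3-methylpiperidin-1-yl the same exchange stays within the scatter (a 1.8-fold higher number from compound 3 to compound 4 (0.24 log units; within the scatter)), so the position shows only a small response to the amide substituent so far. Nothing available here accounts for these steps.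

Still open, going by these compounds, is what a piperazin-1-yl carrying acetyl in place of methylsulfonyl, or a chain ending in a carboxylic acid, would give on this carbonyl carbon.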